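The source may hold more compounds than are shown below. What is called first, only, known or untested is meant among the compounds shown, and "the series" means these compounds.

In an assay on membranes from liver for displacement of a labelled ligand from Sigma intracellular receptor 2 (Rattus norvegicus), read by scintillation counting, with a stated time of 120 min (a lower number here means a stronger inhibitor, a higher number a weaker inhibitor), three compounds built on one shared core have been measured. Compound 1 `Cc1cccc2sc(NC(=O)CCN3CCN(C(C)C)CC3)nc12` gives 1800 nM, compound 2 `Cc1cccc2sc(NC(=O)CCN3CCN(C4CCCCC4)CC3)nc12` gives 233 nM, and compound 3 `Cc1cccc2sc(NC(=O)CCN3CCN(C4CCN(C)CC4)CC3)nc12` gives 3600 nM. Compound 3 thus carries the highest of the three numbers; its nearest neighbour is compound 1, a gap that stays within the scatter, while compound 2 lies furthest away because a 15-fold higher number from compound 2 to compound 3 (1.19 log units; beyond the scatter).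

Compound 4 `Cc1cccc2sc(NC(=O)CCN3CCN(c4ncccn4)CC3)nc12` alters compound 3 in a single place: pyrimidin-2-yl in place of 1-methylpiperidin-4-yl on an amine nitrogen in a ring. All three measured steps also swap the group on this same ring nitrogen, so each of them bears on the new change. Cyclohexyl in place of isopropyl gave a 7.7-fold lower number from compound 1 to compound 2 (0.89 log units; beyond the scatter), 1-methylpiperidin-4-yl in place of isopropyl gave a 2.0-fold higher number from compound 1 to compound 3 (0.30 log units; within the scatter), and 1-methylpiperidin-4-yl in place of cyclohexyl gave a 15-fold higher number from compound 2 to compound 3 (1.19 log units; beyond the scatter). Going by the values given here, none of these steps brings in an aromatic ring, so the pyrimidin-2-yl group has no direct precedent among the measured compounds. What the steps do show is that a six-membered ring at this position can push the number down by a modest to large amount. A lower number than that of compound 3 is therefore expected for compound 4, amounting to a 4.0-fold lower number from compound 3 to compound 4 (0.60 log units; beyond the scatter). Compound 4 is estimated at 900 nM, within a range from 250 nM to 3500 nM.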

Compound 4, inhibition constant: > 1000 nM
Compound 4 gave a limit, no number; the forecaster's own chance of this, stated with the estimate: 5%; middle value at least 1.1-fold (0.04 log units) from the limit.
By their numbers in this assay, from the lowest: compound 2; then compounds 1 and 3 (each within the scatter of the next).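

In this assay compound 4 gives > 1000 nM, which is a limit of the assay and not a number. Pyrimidin-2-yl in place of cyclohexyl gave an at least 4.2-fold higher number from compound 2 to compound 4 (0.63 log units; beyond the scatter), so, like 1-methylpiperidin-4-yl, this six-membered ring holding nitrogen does not keep the low number seen with cyclohexyl, and an aromatic ring on this amine nitrogen does not restore it. The steps to compound 4 from compound 1 and from compound 3 cannot be read, and what is known about the new group rests on a single point: the limit of > 1000 nM in this assay, at which 1 of the 4 values shown sits.

The compounds shown leave open how far compound 4 really lies from compound 1 and compound 3, and so whether the aromatic ring does any better or worse than the other two groups. They also leave open whether the low number of compound 2 depends on a ring made of carbon alone: a phenyl ring on this nitrogen would separate aromatic character from ring nitrogen, and a cyclopentyl or benzyl group would probe ring size and a longer link.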